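The compounds below may be only part of what the source reports. "The series", "measured", "known", "first", "only" and "open" are said of these compounds alone.

Compound 1 `Nc1cc(N)c2nc(-c3ccccc3)c(NCc3ccc(Cl)c(Cl)c3)nc2c1` gives 9770 nM in a functional assay on SW-620 cells (Homo sapiens) for inhibition, read by sulforhodamine B assay, with a stated time of 48 h; on this read-out higher numbers stand for weaker inhibition of growth and lower numbers for stronger inhibition of growth.
Compound 2 `COc1ccc(CNc2nc3cc(N)cc(N)c3nc2-c2ccccc2)cc1OC` gives < 100000 nM in this assay; this is a limit of the assay, not a number.

Compound 1 and compound 2 share one core and differ only in the aryl group on the saturated chain carbon bound to the ring nitrogen. The step that the limit leaves unreadable from compound 1 to compound 2 cannot be read, because the limit of < 100000 nM in this assay, at which 1 of the 2 values shown sits, hides where compound 2 actually stands. Compound 2 therefore stands on the numbers only as a limit.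

Compound 3 `COc1cc(CNc2nc3cc(N)cc(N)c3nc2-c2ccccc2)cc(OC)c1OC` is the next member of the series. Relative to compound 2 the change is methoxy in place of hydrogen on an aromatic carbon. Going by the values given here, the one measured step that bears on it, from compound 1 to compound 2, is of unreadable size, so there is no measured guide to how an added methoxy group on this ring shifts this assay. Compound 3 is expected to sit near compound 2, with a step that the limit leaves unreadable from compound 2 to compound 3 that is estimated, not measured. The estimate for compound 3 in this assay is 30000 nM, within 5000 nM to 100000 nM.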

Compound 3, concentration for total growth inhibition: 4470 nM
Estimate against measurement, compound 3: 6.7-fold (0.83 log units) above; measured number below the stated range.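

Going by these compounds alone, no step from compound 2 to compound 3 can be read in this assay because compound 2 carries a limit and not a number: the limit of < 100000 nM in this assay, at which 1 of the 3 values shown sits.
The compounds shown leave open where compound 2 actually stands, and so how far methoxy in place of hydrogen on this ring moves the read-out.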